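The compounds below may be only part of what the source reports. "The series", "measured", "known", "first", "only" and "open" are said of these compounds alone.

Measured in a functional assay on HeLa cells (Homo sapiens) for inhibition, read by MTT assay, with a stated time of 72 h; a higher number here means a weaker inhibitor, a lower number a stronger inhibitor:
- compound 1 `COc1cc(NC(C)CCCNC(=O)Nc2cccc(F)c2)c2ncccc2c1`: 18000 nM
- compound 2 `COc1cc(NC(C)CCCNC(=O)Nc2ccc(F)cc2)c2ncccc2c1`: 20000 nM
- compound 3 `COc1cc(NC(C)CCCNC(=O)Nc2cc(C(F)(F)F)cc(C(F)(F)F)c2)c2ncccc2c1`: 3100 nM

Compound 2, at 20000 nM, sits within the scatter of compound 1, while compound 3 gives a clearly lower number, 3100 nM. The unmeasured compound 4 `COc1cc(NC(C)CCCNC(=O)Nc2ccc(Cl)cc2)c2ncccc2c1` differs from compound 2 by a single swap: chloro in place of fluoro on an aromatic carbon.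

Going by the values given here, the one measured step that bears on this is a 1.1-fold higher number from compound 1 to compound 2 (0.05 log units; within the scatter). That step moved the fluoro group rather than replacing it, so it offers only indirect guidance. Among the compounds with values here, no measured pair exchanges fluoro for chloro. In this assay, no change beyond the scatter is therefore expected: the expected change is a 1.3-fold lower number from compound 2 to compound 4 (0.12 log units; within the scatter). For compound 4 the estimated value is 15000 nM, with an expected range of 7000 nM to 27000 nM.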

Compound 4, half-maximal inhibitory concentration: 18000 nM
Compound 4: middle estimate off by 1.2-fold (0.08 log units), on the low side; the range from low to high includes it.
By their numbers in this assay, from the lowest: compound 3; then compounds 1, 4 and 2 (each within the scatter of the next).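

Chloro in place of fluoro on this aromatic carbon gives a 1.1-fold lower number from compound 2 to compound 4 (0.05 log units; within the scatter), the first direct reading of this exchange at this position. Changing both the halogen and its place gives no change at the digits printed from compound 1 to compound 4 (within the scatter), so in this assay the 3-fluorophenyl, 4-fluorophenyl and 4-chlorophenyl compounds cannot be told apart. Nothing measured here explains why these compounds read alike.

On these data alone, whether a group other than a halogen, such as an amine or a carboxylic acid, would shift the number at this carbon stays open. So does whether a longer chain would change the picture.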